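Swapping Fluoro for Methyl on the Phenoxy Ring

This account rests on a few compounds, and the source may have more. Where it says the series, first, only, none or still open, it means among the compounds named here.

The measured compounds, each in a functional assay on MGC-803 cells (Homo sapiens) for antiproliferative activity, read by CCK-8 assay, with a stated time of 72 h; a higher number here means a weaker inhibitor, a lower number a stronger inhibitor:
- compound 1, `Nc1ccccc1NC(=O)c1ccc(COc2ccc(Br)cc2)cc1`, gives > 32000 nM, which is a limit of the assay rather than a number
- compound 2, `CCCc1ccc(OCc2ccc(C(=O)Nc3ccccc3N)cc2)cc1`, gives 4420 nM
- compound 3, `Nc1ccccc1NC(=O)c1ccc(COc2ccc(F)cc2)cc1`, gives 4970 nM

Compound 3 and compound 2 sit close together: the step of a 1.1-fold higher number from compound 2 to compound 3 (0.05 log units; within the scatter) lies within the scatter, so neither can be called stronger or weaker. Compound 1 stands apart in that it gives only a limit (the limit of > 32000 nM in this assay, at which 1 of the 3 values shown sits). From that limit, an at least 6.4-fold lower number from compound 1 to compound 3 (0.80 log units; beyond the scatter) and an at least 7.2-fold lower number from compound 1 to compound 2 (0.85 log units; beyond the scatter) both show clear gains when fluoro or propyl replaces bromo.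

Compound 4, `Cc1ccc(OCc2ccc(C(=O)Nc3ccccc3N)cc2)cc1`, differs from compound 3 in one place: methyl in place of fluoro on an aromatic carbon. Among the measured compounds shown here, two measured steps bear on this. Exchanging fluoro for propyl, another alkyl, changed little, as a 1.1-fold higher number from compound 2 to compound 3 (0.05 log units; within the scatter) shows. Exchanging bromo for fluoro, an at least 6.4-fold lower number from compound 1 to compound 3 (0.80 log units; beyond the scatter), was a clear gain, but methyl does not touch that comparison. Methyl is therefore expected to behave like propyl and fluoro here, giving no step beyond the scatter in this assay; the expected step is a 1.1-fold lower number from compound 3 to compound 4 (0.04 log units; within the scatter). Compound 4 is estimated at 4500 nM, with a likely range from 2000 nM to 10000 nM.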

Compound 4, half-maximal inhibitory concentration: 6530 nM
Compound 4: middle estimate off by 1.5-fold (0.16 log units), on the low side, and the stated range covers the measured number.
By their numbers in this assay, from the lowest: compounds 2, 3 and 4 (each within the scatter of the next). At a limit, above all of these: compound 1.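

Methyl, on an aromatic carbon para to a large group, now joins fluoro and propyl in a set that this assay cannot separate: a 1.3-fold higher number from compound 3 to compound 4 (0.12 log units; within the scatter), and likewise a 1.5-fold higher number from compound 2 to compound 4 (0.17 log units; within the scatter). Compounds 2, 3 and 4 therefore show that, among these three groups, neither exchanging fluoro for an alkyl group nor shortening propyl to methyl gives a step beyond the scatter, whereas the earlier compounds offered only the single comparison of fluoro with propyl. Bromo alone stands apart, and an at least 4.9-fold lower number from compound 1 to compound 4 (0.69 log units; beyond the scatter) is the third step away from it to lie beyond the scatter, though its true size stays unknown since compound 1 gives a limit and not a number: the limit of > 32000 nM in this assay, at which 1 of the 4 values shown sits.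

The compounds shown leave open whether chloro would side with fluoro or with bromo, and whether a chain longer than propyl would stay with compounds 2, 3 and 4. They also leave open how plain hydrogen, an amine or a carboxylic acid would read at this same position.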